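Bromo substitution on an isatin-derived thiazolidinone series

The source may hold more compounds than are shown below. What is called first, only, known or untested is meant among the compounds shown, and "the series" means these compounds.

Compound 1 `O=C1N=C(N2N=C(c3ccccc3)CC2c2ccccc2O)S/C1=C1/C(=O)Nc2ccccc21` gives 1990 nM in a functional assay on cells (Cancer cell lines, Homo sapiens) for cytotoxicity, read by sulforhodamine B assay, with a stated time of 48 h; on this read-out higher numbers stand for weaker inhibition of growth and lower numbers for stronger inhibition of growth. Compound 2 `O=C1N=C(N2N=C(c3ccccc3)CC2c2ccccc2O)S/C1=C1/C(=O)Nc2ccc(Br)cc21`, which carries bromo in place of hydrogen on an aromatic carbon, gives 210 nM. That change made a 9.5-fold lower number from compound 1 to compound 2 (0.98 log units; beyond the scatter).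

Compound 3 `COc1ccc(C2CC(c3ccc4ccccc4c3)=NN2C2=NC(=O)/C(=C3\C(=O)Nc4ccccc43)S2)cc1` gives 1680 nM in this assay, a value within the scatter of that of compound 1. The difference between the core of compound 1 and the core of compound 3 is not broken down here.

Compound 4 `COc1ccc(C2CC(c3ccc4ccccc4c3)=NN2C2=NC(=O)/C(=C3\C(=O)Nc4ccc(Br)cc43)S2)cc1` is not yet measured. It differs from compound 3 by bromo in place of hydrogen on an aromatic carbon, the same change as from compound 1 to compound 2, at the same kind of place.

Going by the values given here, the expected step is a 5.6-fold lower number from compound 3 to compound 4 (0.75 log units; beyond the scatter), resting on the single earlier instance a 9.5-fold lower number from compound 1 to compound 2 (0.98 log units; beyond the scatter). A single step does not settle how far the change carries over; the estimate stays cautious. Compound 4 is therefore estimated at 300 nM in this assay. Compound 4 is expected to fall between 120 nM and 800 nM.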

Compound 4, concentration for 50% growth inhibition: 50 nM
Estimate against measurement, compound 4: 6.0-fold (0.78 log units) above; the whole stated range lies above it.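

In this assay, bromo in place of hydrogen on an aromatic carbon again lowers the number on the second core, giving a 34-fold lower number from compound 3 to compound 4 (1.53 log units; beyond the scatter), so the direction of the change carries over between the two cores shown. The size does not carry over, and the two steps stand apart by more than the scatter allows: the same change on two cores in this assay, a 9.5-fold lower number (0.98 log units; beyond the scatter) from compound 1 to compound 2 and a 34-fold lower number (1.53 log units; beyond the scatter) from compound 3 to compound 4, 3.5-fold (0.55 log units) apart, beyond the scatter of two such steps These two pairs show that the benefit of this change is not a fixed amount in this series, but they do not show what sets its size, since the core of compound 1 and the core of compound 3 differ in more than one place, nor do they show how the change would behave on any further core.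

The compounds shown leave open whether chloro, nitro or an amine on the same aromatic carbon would lower the number as bromo does. They also leave open whether the step would keep either size on a core carrying a carboxylic acid or a longer chain in place of the methoxy group.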